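Adding a Second Chloro Group to Compound 3

The source may hold more compounds than are shown below. What is called first, only, known or untested is meant among the compounds shown, and "the series" means these compounds.

Measured so far in a functional assay on HT-29 cells (Homo sapiens) for cytotoxicity, read by MTT assay, with a stated time of 72 h; a lower number here means a stronger inhibitor, a higher number a weaker inhibitor:
compound 1 `COc1cccc(-c2cc(C(=O)Nc3ccc(Oc4ccnc5cc(OCCCN6CCCCC6)c(OC)cc45)c(F)c3)c3ccccc3n2)c1` gives 1740 nM;
compound 2 `COc1cc2c(Oc3ccc(NC(=O)c4cc(-c5ccc(F)cc5)nc5ccccc45)cc3F)ccnc2cc1OCCCN1CCCCC1` gives 130 nM;
compound 3 `COc1cc2c(Oc3ccc(NC(=O)c4cc(-c5cccc(Cl)c5)nc5ccccc45)cc3F)ccnc2cc1OCCCN1CCCCC1` gives 62 nM.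

Compound 3 carries the lowest number of the three, reached by a 2.1-fold lower number from compound 2 to compound 3 (0.32 log units; beyond the scatter) and by a 28-fold lower number from compound 1 to compound 3 (1.45 log units; beyond the scatter). Compound 4 `COc1cc2c(Oc3ccc(NC(=O)c4cc(-c5ccc(Cl)c(Cl)c5)nc5ccccc45)cc3F)ccnc2cc1OCCCN1CCCCC1` differs from it by chloro in place of hydrogen on an aromatic carbon. Among the measured compounds shown here, two measured steps touch this phenyl: a 28-fold lower number from compound 1 to compound 3 (1.45 log units; beyond the scatter), a large one, and a 2.1-fold lower number from compound 2 to compound 3 (0.32 log units; beyond the scatter), a modest one. For the measured compounds named here, both altered the single group on that ring; none of them adds a chloro beside an existing chloro, so the step is expected to be small, probably within the scatter, and if anything downward. Compound 4 is therefore estimated at 50 nM in this assay, within a range from 18 nM to 150 nM, which means an expected step of a 1.2-fold lower number from compound 3 to compound 4 (0.09 log units; within the scatter).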

Compound 4, half-maximal inhibitory concentration: 1210 nM
Estimate against measurement, compound 4: 24-fold (1.38 log units) below; the whole stated range lies below it.
By their numbers in this assay, from the lowest: compound 3; then compound 2; then compounds 4 and 1 (each within the scatter of the next).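

In this assay, a chloro ortho to a chloro group gives a 20-fold higher number from compound 3 to compound 4 (1.29 log units; beyond the scatter), so one added heavy atom on this phenyl can undo the gain seen earlier, and 3,4-dichlorophenyl also gives a 9.3-fold higher number from compound 2 to compound 4 (0.97 log units; beyond the scatter). The result sits level with the 3-methoxyphenyl, at a 1.4-fold lower number from compound 1 to compound 4 (0.16 log units; within the scatter). Nothing available here explains this loss. Still open, as far as these compounds go, is whether the loss follows from chloro itself or from any second group on this ring, a question that a methyl or an amine in the same place would address.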